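The source may hold more compounds than are shown below. What is called first, only, known or untested is meant among the compounds shown, and "the series" means these compounds.

Compound 1 `CC(C)CSc1nc(N)nc2c1ncn2/C=C1/CC1(CO)CO`: in an ADME assay on CCRF-HSB-2 cells (Homo sapiens) for cytotoxicity, with a stated time of 7 days (on this read-out lower numbers stand for higher toxicity in this test and higher numbers for lower toxicity in this test), compound 1 gives 60000 nM.
Compound 2 `Nc1nc(OCc2ccccc2)c2ncn(/C=C3/CC3(CO)CO)c2n1`: in this assay compound 2 gives > 20000 nM, which is a limit of the assay and not a number.

Compound 2 therefore stands only at a limit in this assay, not at a measured number. Going by the values given here, the single step known so far, a step that the limit leaves unreadable from compound 1 to compound 2, cannot be read in size because the limit of > 20000 nM in this assay, at which 1 of the 2 values shown sits, sets a limit rather than a value.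

Compound 3 `Nc1nc(NCc2ccccc2)c2ncn(/C=C3/CC3(CO)CO)c2n1` differs from compound 2 by benzylamino in place of benzyloxy on an aromatic carbon. Among the compounds with values here, only the step from compound 1 to compound 2 bears on this change, and its size is not readable, so there is no measured step here from which a direction or size for compound 3 in this assay can be taken. The account expects compound 3 to sit near the limit of compound 2, and the step it estimates is a step that the limit leaves unreadable from compound 2 to compound 3, a step expected to stay within the scatter. For compound 3 in this assay the estimate is 40000 nM, with an expected range from 15000 nM to 120000 nM.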

Compound 3, half-maximal cytotoxic concentration: > 20000 nM
Compound 3: a limit, no number; the forecaster's own chance of this, stated with the estimate: 60%; the middle value does not contradict the limit.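

Compound 3 gives > 20000 nM in this assay, which is a limit of the assay and not a number. No step from compound 1 or compound 2 to compound 3 can be read in size, because these comparisons rest on a limit: the limit of > 20000 nM in this assay, at which 2 of the 3 values shown sit.

The compounds shown leave open whether benzylamino and benzyloxy differ at all in this test, and how either compares with isobutylsulfanyl.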